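Selenium in Place of Sulfur on Two Bis-Amide Cores

This account rests on a few compounds, and the source may have more. Where it says the series, first, only, none or still open, it means among the compounds named here.

Compound 1 `CS/C(=N\C(=O)c1sccc1Cl)NC(=O)c1sccc1Cl`: 78900 nM
Compound 2 `CS/C(=N\C(=O)c1cc(-c2ccccc2)nc2ccccc12)NC(=O)c1cc(-c2ccccc2)nc2ccccc12`: > 100000 nM
Compound 3 `C[Se]/C(=N\C(=O)c1cc(-c2ccccc2)nc2ccccc12)NC(=O)c1cc(-c2ccccc2)nc2ccccc12`: 30600 nM

All values come from a functional assay on K562 cells (Homo sapiens) for cytotoxicity, read by MTT assay, with a stated time of 72 h; on this read-out higher numbers stand for weaker inhibition of growth and lower numbers for stronger inhibition of growth. Compound 2 gives only > 100000 nM, which is a limit of the assay and not a number. Compound 3 gives 30600 nM. The change between them is a group of 2 heavy atoms (1 carbon, 1 selenium; no ring) in place of a group of 2 heavy atoms (1 carbon, 1 sulfur; no ring), on a carbon with a double bond to nitrogen, and it made the step of an at least 3.2-fold lower number from compound 2 to compound 3 (0.51 log units; beyond the scatter); the step can only be given as a lower bound because the limit of > 100000 nM in this assay, at which 1 of the 3 values shown sits, applies to compound 2. Compound 1 gives 78900 nM, a higher number than compound 3, and the difference between its core and that of compound 2 is not broken down here.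

Compound 4 `C[Se]/C(=N\C(=O)c1sccc1Cl)NC(=O)c1sccc1Cl` is not yet measured. It differs from compound 1 by a group of 2 heavy atoms (1 carbon, 1 selenium; no ring) in place of a group of 2 heavy atoms (1 carbon, 1 sulfur; no ring), on a carbon with a double bond to nitrogen, the same change that was made from compound 2 to compound 3, at the same kind of place. The step from compound 1 to compound 4 is expected to be a 3.2-fold lower number from compound 1 to compound 4 (0.50 log units; beyond the scatter), resting on an at least 3.2-fold lower number from compound 2 to compound 3 (0.51 log units; beyond the scatter). Compound 4 is therefore estimated at 25000 nM, with a likely range from 8000 nM to 80000 nM.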

Compound 4, concentration for total growth inhibition: 28500 nM
The estimate for compound 4 lay 1.1-fold (0.06 log units) below the measured number, within the range that was stated.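

In this assay, placing the carbon-and-selenium group where methylsulfanyl stood on the second core gave a 2.8-fold lower number from compound 1 to compound 4 (0.44 log units; beyond the scatter), so the number fell on this core too. Set side by side, the two steps point the same way: the same change on two cores in this assay, an at least 3.2-fold lower number (0.51 log units; beyond the scatter) from compound 2 to compound 3 and a 2.8-fold lower number (0.44 log units; beyond the scatter) from compound 1 to compound 4; the limit leaves it open whether they differ. Going by these compounds, two cores make no rule for a whole series, and compound 2 sits at a limit of the assay and not a number, so how closely the two steps match stays unknown: the limit of > 100000 nM in this assay, at which 1 of the 4 values shown sits.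

The compounds shown carry only methylsulfanyl and its selenium counterpart on the carbon with a double bond to nitrogen, so it stays open how an amine or a longer chain would read at that place. They also leave open whether the same lowering would appear on a core bearing a carboxylic acid, and they offer no explanation for why the number falls.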